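From 3-cyanophenyl to 4-methoxyphenyl on the shared core

The compounds below may be only part of what the source reports. "The series", "measured", "known", "first", "only" and "open" are said of these compounds alone.

Values measured in a functional assay on A549 cells (Homo sapiens) for antiproliferative activity, read by MTT assay, with a stated time of 72 h; a lower number here means a stronger inhibitor, a higher number a weaker inhibitor
- compound 1 `CC/C=C/C(=O)Nc1cccc(Oc2nc(Nc3ccn(C)n3)nc3c2CSCC3)c1` gives 36800 nM
- compound 2 `CC/C=C/C(=O)Nc1cccc(Oc2nc(Nc3cccc(C#N)c3)nc3c2CSCC3)c1` gives 10100 nM

Compound 2 holds the lower of these two numbers, which makes it the stronger inhibitor of the pair. Compound 3 `CC/C=C/C(=O)Nc1cccc(Oc2nc(Nc3ccc(OC)cc3)nc3c2CSCC3)c1` carries 4-methoxyphenyl in place of 3-cyanophenyl on a nitrogen on an aromatic ring. Among the measured compounds shown here, only one measured step changes this place, a 3.6-fold lower number from compound 1 to compound 2 (0.56 log units; beyond the scatter), and it involved a different pair of groups. It offers modest guidance, so no clear direction can be drawn from it. The expected change stays within the usual scatter, a 1.4-fold higher number from compound 2 to compound 3 (0.14 log units; within the scatter). For compound 3 the estimated value is 14000 nM, with an expected range from 5000 nM to 35000 nM.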

Compound 3, half-maximal inhibitory concentration: 20100 nM
For compound 3 the middle estimate is 1.4-fold (0.16 log units) below the measured one; the measured number falls inside the stated range.
By their numbers in this assay, from the lowest: compounds 2, 3 and 1 (each within the scatter of the next, the first and the last beyond it).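

In this assay, the change from 3-cyanophenyl to 4-methoxyphenyl gives a 2.0-fold higher number from compound 2 to compound 3 (0.30 log units; within the scatter) and so does not clearly separate these two groups on this nitrogen. The change from 1-methyl-1H-pyrazol-3-yl to 4-methoxyphenyl gives a 1.8-fold lower number from compound 1 to compound 3 (0.26 log units; within the scatter) and also stays too small to read as a real difference. No supporting data on the cause are available. Going by these compounds, whether a plain phenyl, or a phenyl carrying an amine or a carboxylic acid, would shift the number beyond the scatter remains open.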